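Trifluoromethyl added to a chloro-substituted tetrazole

The source may report more compounds than this note shows. Statements on the series, on what has been measured and on what is new or still open speak of the compounds shown alone.

Compound 2 `Clc1ccccc1-c1nnnn1Cc1cccnc1` gives 15800 nM in an in vitro functional assay on 1321-N1 cells for antagonist activity at P2X purinoceptor 7 (Homo sapiens), read by FLIPR and calcium flux (on this read-out lower numbers stand for stronger inhibition and higher numbers for weaker inhibition), the lowest of the two numbers shown, though compound 1 `c1ccc(-c2nnnn2Cc2cccnc2)cc1` with 25100 nM lies within the scatter of it. Compound 3 `FC(F)(F)c1cccc(-c2nnnn2Cc2cccnc2)c1Cl` differs from compound 2 by trifluoromethyl in place of hydrogen on an aromatic carbon. Within the data shown here, the only measured step, a 1.6-fold lower number from compound 1 to compound 2 (0.20 log units; within the scatter), concerns a different change and gives little guidance for a trifluoromethyl entering in this place. A moderate step is therefore expected, a 2.0-fold lower number from compound 2 to compound 3 (0.30 log units; within the scatter), with wide uncertainty. Compound 3 is estimated at 8000 nM, in the range 2500 nM to 25000 nM.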

Compound 3, half-maximal inhibitory concentration: 12.6 nM
For compound 3 the middle estimate is 630-fold (2.80 log units) above the measured one, and the stated range ends above it.
By their numbers in this assay, from the lowest: compound 3; then compounds 2 and 1 (each within the scatter of the next).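

In this assay, trifluoromethyl in place of hydrogen on an aromatic carbon, ortho to a chloro group, gives a 1300-fold lower number from compound 2 to compound 3 (3.10 log units; beyond the scatter), so this position can change the read-out far more than the earlier step within the scatter suggested. The data shown offer no explanation for a step of this size. Going by these compounds, it remains open whether trifluoromethyl would give a similar step on compound 1, without the chloro group. On these data alone, it also remains open whether a nitrile, a methoxy group or an amine would do so in this place.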